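Sulfonamide nitrogen ethylation in an imidazolium oxime series

The source may report more compounds than this note shows. Statements on the series, on what has been measured and on what is new or still open speak of the compounds shown alone.

Working notes. In a physicochemical assay for lipophilicity (on this read-out lower numbers stand for lower lipophilicity and higher numbers for higher lipophilicity), compound 3 `C[n+]1ccn(CCNS(=O)(=O)c2ccccc2)c1/C=N/O` gives -1.92, the second highest of the three numbers; compound 1 `CCN(CCn1cc[n+](C)c1/C=N/O)S(C)(=O)=O` gives -2.72 and compound 2 `CCN(CCn1cc[n+](C)c1/C=N/O)S(=O)(=O)C(F)(F)F` gives -1.03. Going by the values given here, the only step recorded between measured compounds, a number 1.69 log units higher from compound 1 to compound 2 (beyond the scatter), concerns the group on the sulfonyl sulfur and not the sulfonamide nitrogen. Among the compounds with values here, compound 4 `CCN(CCn1cc[n+](C)c1/C=N/O)S(=O)(=O)c1ccccc1` differs from compound 3 by ethyl in place of hydrogen on a sulfonamide nitrogen, a change for which no measured step exists in this set. A moderate rise in this assay, beyond the scatter, is expected for compound 4 from the addition of the ethyl group, a number 0.72 log units higher from compound 3 to compound 4 (beyond the scatter). Compound 4 is therefore estimated at -1.2, with a range from -1.8 to -0.6.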

Compound 4, distribution coefficient: -1.39
The estimate for compound 4 lay 0.19 log units above the measured number; the measured number falls inside the stated range.
By their numbers in this assay, from the lowest: compound 1; then compound 3; then compound 4; then compound 2.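

In this assay, ethyl in place of hydrogen on a sulfonamide nitrogen gives the first step read at this position: a number 0.53 log units higher from compound 3 to compound 4 (beyond the scatter). With ethyl on that nitrogen throughout, phenyl on the sulfonyl sulfur can now be set against the other two groups, in place of methyl giving a number 1.33 log units higher from compound 1 to compound 4 (beyond the scatter) and in place of trifluoromethyl giving a number 0.36 log units lower from compound 2 to compound 4 (beyond the scatter). No supporting measurement bears on the origin of these steps.

The nitrogen change is read only with phenyl on the sulfonyl sulfur. Going by these compounds, its size with methyl or trifluoromethyl there stays open, as does the step for a longer chain or a carboxylic acid on that nitrogen.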